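The source may hold more compounds than are shown below. What is called first, only, known or untested is meant among the compounds shown, and "the series" means these compounds.

Measured in a functional assay, read by spectrophotometry; a lower number here means that less compound is needed, a higher number that more compound is needed for the effect:
- compound 1 `COc1ccc(-c2cc(=O)c3ccc(OCCCCN4CCC(C)CC4)cc3o2)cc1`: 28.1 nM
- compound 2 `COc1ccc(-c2cc(=O)c3ccc(OCCCCN4CCC(CCO)CC4)cc3o2)cc1`: 23.2 nM
- compound 3 `COc1ccc(-c2cc(=O)c3ccc(OCCCCCCN4CCC(C)CC4)cc3o2)cc1`: 32.6 nM

Compound 3 cannot be separated from the other two, as a 1.2-fold higher number from compound 1 to compound 3 (0.06 log units; within the scatter) and a 1.4-fold higher number from compound 2 to compound 3 (0.15 log units; within the scatter) both stay inside the usual scatter. All three compounds therefore sit at one level in this assay.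

The next compound is compound 4 `COc1ccc(-c2cc(=O)c3ccc(OCCCCCCCN4CCC(CCO)CC4)cc3o2)cc1`. Its difference from compound 3 is (4-(2-hydroxyethyl)piperidin-1-yl)methyl in place of 4-methylpiperidin-1-yl on a saturated chain carbon, six bonds along the chain from an oxygen on an aromatic ring. In words, (4-(2-hydroxyethyl)piperidin-1-yl)methyl stands in place of 4-methylpiperidin-1-yl on a saturated chain carbon, six bonds along the chain from an oxygen on an aromatic ring. The change thus joins a longer chain to the ring group of compound 2.

Among the compounds with values here, two measured steps bear on each part. The ring group alone came with a 1.2-fold lower number from compound 1 to compound 2 (0.08 log units; within the scatter), and a longer chain alone came with a 1.2-fold higher number from compound 1 to compound 3 (0.06 log units; within the scatter). Neither step leaves the scatter, so no real shift is expected in this assay. Within the data shown here, no measured compound has a chain as long as that of compound 4, however, so the range is kept wide.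

The expected step is a 1.1-fold lower number from compound 3 to compound 4 (0.04 log units; within the scatter), an estimate that stays within the scatter. For compound 4 the estimated value is 30 nM, with an expected range from 13 nM to 70 nM.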

Compound 4, half-maximal effective concentration: 35.7 nM
The estimate for compound 4 lay 1.2-fold (0.08 log units) below the measured number; low and high end bracket the measured number.
By their numbers in this assay, from the lowest: compounds 2, 1, 3 and 4 (each within the scatter of the next).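

In this assay, (4-(2-hydroxyethyl)piperidin-1-yl)methyl in place of 4-methylpiperidin-1-yl, on a saturated chain carbon six bonds along the chain from an oxygen on an aromatic ring, comes with a 1.1-fold higher number from compound 3 to compound 4 (0.04 log units; within the scatter), so the longer chain and the hydroxyethyl group together do not move compound 4 away from the level of compound 3. The comparisons with the two shorter-chain compounds read the same way, with a 1.5-fold higher number from compound 2 to compound 4 (0.19 log units; within the scatter) and a 1.3-fold higher number from compound 1 to compound 4 (0.10 log units; within the scatter), so all four compounds now sit at one level, and this position accepts the longest chain shown here without a real shift in the number. No information is at hand that would explain this flat result.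

The compounds shown leave open how far this tolerance reaches, for instance whether a much shorter or still longer chain would leave the level. They also leave open whether an amine or a carboxylic acid in place of the hydroxyl group, or a morpholine in place of the piperidine, would move the number beyond the scatter.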